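This account rests on a few compounds, and the source may have more. Where it says the series, first, only, none or still open, it means among the compounds named here.

For the measured compounds named here, compound 3, `O=C(CCc1ccc(C(F)(F)F)cc1)Nc1ccc2nc(N3CC4CC3CN4)ccc2c1`, stands at the top of the three numbers so far measured in an assay on isolated protein for displacement of a labelled ligand from melanin-concentrating hormone receptor 1 (Homo sapiens); a higher number here means a weaker inhibitor, a lower number a stronger inhibitor: compound 3 gives 210 nM, while compound 1, `O=C(CCc1ccc(C(F)(F)F)cc1)Nc1ccc2nc(N3CCCCC3)ccc2c1`, gives 12 nM and compound 2, `CC(C)N(C)c1ccc2cc(NC(=O)CCc3ccc(C(F)(F)F)cc3)ccc2n1`, gives 2 nM. Both neighbours sit far lower, with an 18-fold higher number from compound 1 to compound 3 (1.24 log units; beyond the scatter) and a 110-fold higher number from compound 2 to compound 3 (2.02 log units; beyond the scatter). The step from compound 1 to compound 2, a 6.0-fold lower number from compound 1 to compound 2 (0.78 log units; beyond the scatter), shows that an acyclic amine at this position is also well tolerated relative to a ring.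

Compound 4, `CCN(CC)c1ccc2cc(NC(=O)CCc3ccc(C(F)(F)F)cc3)ccc2n1`, is reached from compound 3 by the change (a group of 5 heavy atoms (4 carbon, 1 nitrogen; no ring) in place of a group of 7 heavy atoms (5 carbon, 2 nitrogen; 2 five-membered non-aromatic rings with 1 hetero atom each), on an aromatic carbon). Going by the values given here, the nearest precedent is the step from compound 2 to compound 3, since diethylamino, like isopropyl(methyl)amino, is an acyclic amine of 5 heavy atoms at the same aromatic carbon. Reversing that step points to a large fall in the number for compound 4, while the step from compound 1 to compound 3 sets a smaller lower bound for such a fall. Compound 4 is therefore expected to land near compound 2 and below compound 1, with an estimated 53-fold lower number from compound 3 to compound 4 (1.72 log units; beyond the scatter). The estimate for compound 4 in this assay is 4 nM, within the range 1.5 nM to 15 nM.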

Compound 4, half-maximal inhibitory concentration: 88 nM
The estimate for compound 4 lay 22-fold (1.34 log units) below the measured number, outside the stated range (above it).
By their numbers in this assay, from the lowest: compound 2; then compound 1; then compound 4; then compound 3.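

In this assay, this position separates two acyclic amines of the same size: with a 44-fold higher number from compound 2 to compound 4 (1.64 log units; beyond the scatter), swapping isopropyl(methyl)amino for diethylamino costs far more than any ring-for-chain comparison would have suggested, so the earlier tolerance of an acyclic amine holds for isopropyl(methyl)amino but does not extend to diethylamino. Having no ring is therefore not enough to give a low number, as a 7.3-fold higher number from compound 1 to compound 4 (0.87 log units; beyond the scatter) places diethylamino on the weaker side of piperidin-1-yl, and a 2.4-fold lower number from compound 3 to compound 4 (0.38 log units; beyond the scatter) leaves it only modestly better than the group of compound 3, despite the loss of that group's rings and its hydrogen-bond donor. Nothing available here bears on why these changes have the sizes they do.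

The compounds shown leave open how other amines would fall at this position, such as dimethylamino, N-ethyl-N-methylamino, pyrrolidin-1-yl or morpholin-4-yl, and so whether compound 2 or compound 4 is the exception among acyclic amines. They also leave open whether the high number of compound 3 would persist with a methyl group on the free ring nitrogen of its group.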